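The compounds below may be only part of what the source reports. "The series", "measured", "known", "first", "only" and "open" are said of these compounds alone.

In a functional assay on HEK293 cells for antagonist activity at transient receptor potential cation channel subfamily V member 1 (Homo sapiens), read by calcium flux (a lower number here means a stronger inhibitor, a higher number a weaker inhibitor), compound 1 `FC(F)(F)c1ccc(Nc2ncnc3sc(Nc4c(Cl)cccc4Cl)nc23)cc1` gives 12 nM. Compound 2 `FC(F)(F)c1ccc(Nc2cccc3sc(Nc4c(Cl)cccc4Cl)nc23)cc1` reaches only the limit of > 5000 nM in this assay. Compound 3 `CN(c1nc2c(Nc3ccc(C(F)(F)F)cc3)ncnc2s1)c1c(Cl)cccc1Cl` gives 502 nM, the highest of the two numbers shown. Within the data shown here, the one measured step is a 42-fold higher number from compound 1 to compound 3 (1.62 log units; beyond the scatter), a methyl placed on a ring nitrogen. Compound 4 `CSc1ccccc1Nc1nc2c(Nc3ccc(C(F)(F)F)cc3)ncnc2s1` differs from compound 3 in one place: (2-(methylsulfanyl)phenyl)amino in place of (2,6-dichlorophenyl)(methyl)amino on an aromatic carbon. This change removes that methyl again and at the same time exchanges the attached ring. Among the measured compounds shown here, only the step from compound 1 to compound 3 bears on it, and since that step was large, a step downward beyond the scatter is expected for compound 4, namely a 13-fold lower number from compound 3 to compound 4 (1.10 log units; beyond the scatter). Compound 4 is therefore estimated at 40 nM, with a likely range from 8 nM to 250 nM.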

Compound 4, half-maximal inhibitory concentration: 43 nM
The estimate for compound 4 lay 1.1-fold (0.03 log units) below the measured number, within the range that was stated.
By their numbers in this assay, from the lowest: compound 1; then compound 4; then compound 3. At a limit, above all of these: compound 2.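

The step of a 12-fold lower number from compound 3 to compound 4 (1.07 log units; beyond the scatter) shows that a 2-(methylsulfanyl)phenyl ring on a nitrogen that carries hydrogen restores much of the lost strength, although this step changes both the methyl and the ring. Even so, a 3.6-fold higher number from compound 1 to compound 4 (0.55 log units; beyond the scatter) separates this ring from 2,6-dichlorophenyl on the same nitrogen, so the ring itself counts, not only the methyl.

As far as these compounds go, whether a methoxy group could replace methylsulfanyl remains open. Why the two rings differ is not explained by anything shown.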